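A few compounds are considered here, and "the series" means these few. Any claim that something is new, unique, unknown or untested is made for them only; others in the source may bear on it.

Compound 1 `CCOC(=O)CCCCCOc1cccc(CN(C(=O)c2ccc(-c3ccc4[nH]ccc4c3)cc2)C(C)C)c1`: > 26000 nM
Compound 2 `CCOC(=O)CCCCCOc1cccc(CN(C(=O)c2ccc(-c3cccc(OCC)c3)cc2)C(C)C)c1`: > 22300 nM

In an ADME assay on HepG2 cells (Homo sapiens) for cytotoxicity, read by CellTiter-Glo and resazurin assay, with a stated time of 72 h (a lower number here means that less compound is needed, a higher number that more compound is needed for the effect), compound 2 gives only a limit, not a number. Compound 1 likewise gives only a limit in this assay. Within the data shown here, the single measured step, a step that the two limits leave unreadable from compound 1 to compound 2, therefore cannot be read in size, since both ends sit at the limit of > 22300 nM in this assay, at which 1 of the 2 values shown sits, and (the limit of > 26000 nM in this assay, at which 1 of the 2 values shown sits). Among the measured compounds shown here, compound 2 thus stands at a limit, and the one further value shown is a limit as well.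

Compound 3 `CCOC(=O)CCCCCOc1cccc(CN(C(=O)c2ccc(-c3cccc([N+](=O)[O-])c3)cc2)C(C)C)c1` differs from compound 2 by nitro in place of ethoxy on an aromatic carbon. For the measured compounds named here, no measured step informs this change with a readable size: the only step available, a step that the two limits leave unreadable from compound 1 to compound 2, remains unreadable. No step beyond the scatter is therefore expected in this assay, and the step that the limit leaves unreadable from compound 2 to compound 3 is an estimate resting on two limits only. Compound 3 is consequently expected to give 30000 nM, with a range from 10000 nM to 90000 nM, most likely again as a limit rather than a number.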

Compound 3, half-maximal effective concentration: > 26000 nM
Compound 3 gave a limit, no number; the forecaster's own chance of this, stated with the estimate: 80%; the middle value does not contradict the limit.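

In this assay compound 3 gives only a limit, and its steps from compound 1 and compound 2 cannot be read in size. The compounds shown leave open where the half-maximal effective concentrations of compound 1, compound 2 and compound 3 actually lie, and whether they differ.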